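Cytotoxicity of thiophene-bearing amides on Vero cells

The compounds below may be only part of what the source reports. "The series", "measured", "known", "first", "only" and "open" are said of these compounds alone.

Measured compounds in an ADME assay on Vero cells (Chlorocebus sabaeus) for cytotoxicity, read by XTT assay, with a stated time of 72 h; a higher number here means that more compound is tolerated, a lower number that less compound is tolerated:
- compound 1, `CC1=C(C(=O)Nc2ccccn2)C(c2cccs2)NC(=O)N1`, gives > 100000 nM
- compound 2, `CC1=C(C(=O)Nc2cccnc2)C(c2cccs2)NC(=O)N1`, gives > 100000 nM
- compound 3, `CC1=C(C(=O)Nc2ccccc2Cl)C(c2cccs2)NC(=O)N1`, gives > 100000 nM

Each of these three values is a limit of this assay and not a number. Compound 3 therefore stands only at a limit in this assay, and the two other values shown stand at the same limit. The steps between the measured compounds are accordingly unreadable: a step that the two limits leave unreadable from compound 1 to compound 2, a step that the two limits leave unreadable from compound 1 to compound 3 and a step that the two limits leave unreadable from compound 2 to compound 3. What the three share is the limit of > 100000 nM in this assay, at which 3 of the 3 values shown sit.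

Compound 4, `CC1=C(C(=O)Nc2cccc(Cl)c2)C(c2cccs2)NC(=O)N1`, has not yet been measured in this assay. It differs from compound 3 in one place: 3-chlorophenyl in place of 2-chlorophenyl on an amide-type nitrogen. None of the measured steps bears on a chlorine moved within a phenyl ring, and the steps that are shown give no readable size at all. The estimate for compound 4 can therefore rest only on the limit at which compound 3 and its two neighbours sit, and the expectation is that compound 4 again sits at or near that limit, so that the expected step is a step that the limit leaves unreadable from compound 3 to compound 4. Compound 4 is estimated at 150000 nM, between 50000 nM and 500000 nM, with a high chance that this assay again reports only a limit.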

Compound 4, half-maximal cytotoxic concentration: > 100000 nM
Compound 4: no number, only a limit; the forecaster's own chance of this, stated with the estimate: 85%; the middle value is on the limit's open side.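

In this assay compound 4 gives > 100000 nM, which is a limit of the assay and not a number. No step from compound 1, compound 2 or compound 3 to compound 4 can be read, and all that the four compounds share is this:  the limit of > 100000 nM in this assay, at which 4 of the 4 values shown sit.

The compounds shown leave open how far each true value lies from that limit, and whether 3-chlorophenyl and 2-chlorophenyl differ at all in this read-out.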